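Second Chloro on the Aromatic Ring of Compound 2

The compounds below may be only part of what the source reports. "The series", "measured", "known", "first", "only" and "open" are said of these compounds alone.

Of the compounds shown here, three sharing one core have been tested in a functional assay on KB cells (Homo sapiens) for antiproliferative activity, read by sulforhodamine B assay, tested at 100 ug/mL; on this read-out lower numbers stand for less inhibition and higher numbers for more inhibition at the one concentration tested (going by the name of the read-out). Compound 1 `O=C1CCCCC1S(=O)(=O)Nc1ccc(Cl)cc1C(F)(F)F` gives 11.2%. Compound 2 `O=C1CCCCC1S(=O)(=O)Nc1ccc(Cl)cc1` gives -3.83%, and compound 3 `O=C1CCCCC1S(=O)(=O)N1CCOCC1` gives -4.35%. On these numbers compound 2 stands second of three: its value and that of compound 3 lie within the scatter of each other, while compound 1 lies above it beyond the scatter. Among the measured compounds shown here, the one step between compounds differing in a single place is a number 15 percentage points lower from compound 1 to compound 2 (beyond the scatter), a modest drop.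

Compound 4 `O=C1CCCCC1S(=O)(=O)Nc1ccc(Cl)c(Cl)c1` differs from compound 2 in one place: chloro in place of hydrogen on an aromatic carbon. For the measured compounds named here, no measured step touches this particular change; the only step known concerns a trifluoromethyl, not a chloro, so it bears on compound 4 only loosely, showing that a single substituent on this ring can shift this assay modestly. A small step is therefore expected, likely within the scatter, leaning slightly upward. The estimate for compound 4 is 2%, with a range from -10% to 15%. This estimate means a step of a number 5.8 percentage points higher from compound 2 to compound 4 (within the scatter), expected rather than known.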

Compound 4, a percentage reported as inhibition, at one concentration (the size of the read-out at that concentration, not a potency): 17.8%
Estimate against measurement, compound 4: 15.8 percentage points below, outside the stated range (above it).
By their numbers in this assay, from the lowest: compounds 3 and 2 (each within the scatter of the next); then compounds 1 and 4 (each within the scatter of the next).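

In this assay, putting chloro in place of hydrogen on this aromatic carbon, ortho to a chloro group and meta to a large group, gives a number 21.6 percentage points higher from compound 2 to compound 4 (beyond the scatter). This position is therefore not silent: one added chlorine atom moves the read-out beyond the scatter, a modest step of the same class as a number 15 percentage points lower from compound 1 to compound 2 (beyond the scatter), which concerns trifluoromethyl rather than chloro. No measurement here accounts for the size of this step.

The compounds shown leave open whether this step is tied to chloro or whether a methyl, a methoxy, a nitrile or an amine on the same carbon would give a similar one. The read-out also comes from one concentration, so it gives no potency for compound 4.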